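A few compounds are considered here, and "the series" means these few. Any claim that something is new, unique, unknown or untested is made for them only; others in the source may bear on it.

For the measured compounds named here, in a functional assay on U2OS cells for antagonist activity at proto-oncogene Wnt-3 (Homo sapiens), read by a luciferase reporter, with a stated time of 18 h (on this read-out higher numbers stand for an effect only at larger amounts of compound and lower numbers for an effect already at smaller amounts), compound 3 `CC(C)C(=O)N1CCC[C@H]1C(=O)N1CCC(NS(=O)(=O)c2cc(S(=O)(=O)c3ccccc3)ccc2C(F)(F)F)CC1` gives 90 nM and stands second highest of the three numbers so far: nearest to it is compound 2 `CC(C)(C)OC(=O)N1CCC[C@H]1C(=O)N1CCC(NS(=O)(=O)c2cc(S(=O)(=O)c3ccccc3)ccc2C(F)(F)F)CC1` with 60 nM, a gap that is a 1.5-fold higher number from compound 2 to compound 3 (0.18 log units; within the scatter), and furthest from it is compound 1 `O=C(Cn1ccnc1)N1CCC(NS(=O)(=O)c2cc(S(=O)(=O)c3ccccc3)ccc2C(F)(F)F)CC1` with 230 nM, where the steps of a 3.8-fold lower number from compound 1 to compound 2 (0.58 log units; beyond the scatter) and a 2.6-fold lower number from compound 1 to compound 3 (0.41 log units; beyond the scatter) both run beyond the scatter. Compound 4 `CC(C)(C)NC(=O)N1CCC[C@H]1C(=O)N1CCC(NS(=O)(=O)c2cc(S(=O)(=O)c3ccccc3)ccc2C(F)(F)F)CC1` is not yet measured; it differs from compound 3 by (tert-butyl)amino in place of isopropyl on a carbonyl carbon. Going by the values given here, of the measured steps, only the one on this same carbonyl carbon bears directly on it, and that step, a 1.5-fold higher number from compound 2 to compound 3 (0.18 log units; within the scatter), stayed within the scatter. The other two steps exchanged the whole group on the carbonyl and are less comparable. On this basis a small step, if any, is expected in this assay, most likely toward a somewhat lower number as seen for compound 2 with 60 nM. The expected step is a 1.3-fold lower number from compound 3 to compound 4 (0.11 log units; within the scatter), so compound 4 is estimated at 70 nM, with a range from 35 nM to 140 nM.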

Compound 4, half-maximal effective concentration: 30 nM
Beside the measured number, compound 4's estimate is 2.3-fold (0.37 log units) above it; measured number outside the range, below it.
By their numbers in this assay, from the lowest: compounds 4, 2 and 3 (each within the scatter of the next, the first and the last beyond it); then compound 1.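

In this assay, this carbonyl carbon proves sensitive to the group it carries: the earlier step here stayed within the scatter, whereas (tert-butyl)amino in place of isopropyl gives a 3.0-fold lower number from compound 3 to compound 4 (0.48 log units; beyond the scatter), beyond it. Against tert-butoxy, the same group gives a 2.0-fold lower number from compound 2 to compound 4 (0.30 log units; within the scatter), within the scatter, while the exchange of the whole group on the carbonyl gives a 7.7-fold lower number from compound 1 to compound 4 (0.88 log units; beyond the scatter), the largest step among these compounds. No supporting data are available to explain these steps.

The change from isopropyl to (tert-butyl)amino adds both heavy atoms and a hydrogen-bond donor, so the compounds shown do not separate these two differences. On these data alone, a tert-butyl group directly on the carbonyl carbon, or a smaller methylamino group, would bear on this question, and how either would read out remains open.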